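The compounds below may be only part of what the source reports. "The series", "measured", "known", "first", "only" and "open" are said of these compounds alone.

For the measured compounds named here, in a functional assay for inhibition, read by spectrophotometry, with a stated time of 20 min, tested at 2 mg/mL (a higher number here means a stronger effect of the compound at the concentration tested, a lower number a weaker effect), compound 2 `CC(=O)c1ccc(NC(=O)C2CC(O)CN2S(=O)(=O)c2ccccc2)cc1` gives 45%, the higher of the two numbers so far. Compound 1 `CC(=O)c1ccc(NC(=O)C2CCCN2S(=O)(=O)c2ccc([N+](=O)[O-])cc2)cc1` gives 23.5% in this assay, a number well beyond the scatter below compound 2; as the two compounds differ in more than one place, their values are simply set side by side. The next compound, compound 3 `CC(=O)c1ccc(NC(=O)C2CCCN2S(=O)(=O)c2ccccc2)cc1`, keeps the whole of compound 2 except at one point: hydrogen in place of hydroxy on a saturated ring carbon. Going by the values given here, no step between two measured compounds isolates this change, so its size in this assay can only be guessed from the present pair. Compound 3 is expected to sit somewhat below compound 2, by a step of a number 12 percentage points lower from compound 2 to compound 3 (beyond the scatter) that may or may not exceed the scatter. On that basis compound 3 is estimated to give 33% in this assay, with a likely range from 15% to 50%.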

Compound 3, a percentage reported as inhibition, at one concentration (the size of the read-out at that concentration, not a potency): 25.8%
Beside the measured number, compound 3's estimate is 7.2 percentage points above it; the range from low to high includes it.
By their numbers in this assay, from the lowest: compounds 1 and 3 (each within the scatter of the next); then compound 2.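

In this assay, hydrogen in place of hydroxy on a saturated ring carbon gives a number 19.2 percentage points lower from compound 2 to compound 3 (beyond the scatter), which shows that this ring position matters for the read-out and puts a size on the loss of the hydroxy, something the earlier pair could not do. Hydrogen in place of nitro on an aromatic carbon gives a number 2.3 percentage points higher from compound 1 to compound 3 (within the scatter), so without the hydroxy, compound 1 and compound 3 cannot be told apart in this assay. Nothing available here speaks to the reason for either step.

As far as these compounds go, whether a methoxy, an amine or a fluorine on the same ring carbon would match the hydroxy remains open. From the compounds shown here alone, it is also open whether the hydroxy step keeps its size with nitro on the aromatic carbon, and how a chlorine or a carboxylic acid would fare there.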